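Same Atoms, One Double Bond Drawn as E

The source may report more compounds than this note shows. Statements on the series, on what has been measured and on what is new or still open speak of the compounds shown alone.

In a functional assay on MCF7 cells (Homo sapiens) for cytotoxicity, read by MTT assay, with a stated time of 48 h (a higher number here means a weaker inhibitor, a lower number a stronger inhibitor), three compounds with a shared core have been measured. Compound 1 (`CC(=NNC(=S)Nc1cccc([N+](=O)[O-])c1)c1ccccn1`) gives 38 nM with a nitro group on an aromatic carbon. Compound 2 (`CC(=NNC(=S)Nc1cccc(I)c1)c1ccccn1`) carries iodo in that place and gives 45 nM in the same test. Compound 3 (`CC(=NNC(=S)Nc1ccccc1)c1ccccn1`) has hydrogen there and gives 0.18 nM as its result.

Compound 2 therefore stands at the high end of the numbers, level with the nitro compound: the step is a 1.2-fold higher number from compound 1 to compound 2 (0.07 log units; within the scatter) and no more. Removing either group is a far larger matter, with a 250-fold lower number from compound 2 to compound 3 (2.40 log units; beyond the scatter) and a 210-fold lower number from compound 1 to compound 3 (2.32 log units; beyond the scatter) as the two steps.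

Compound 4 (`C/C(=N\NC(=S)Nc1cccc(I)c1)c1ccccn1`) departs from compound 2 in one respect only: the two compounds have the same atoms and bonds; at least one stereo element is drawn with a configuration in one of them and without one in the other: 1 of 1 stereo elements differ; a double bond is drawn without a configuration in compound 2 and E in compound 4 and nothing else. Among the compounds with values here, none of the measured steps touches that double bond, since each exchanges a group on an aromatic carbon, so the large steps offer no guide here. With the same atoms and bonds, no step beyond the scatter is expected in this assay, and the expected step is no change at the digits printed from compound 2 to compound 4 (within the scatter) at most in size. This expectation rests on compound 2 at 45 nM as the anchor. Compound 4 is therefore estimated at 45 nM (expected range 15 nM to 130 nM).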

Compound 4, half-maximal inhibitory concentration: 45 nM
Estimate against measurement, compound 4: no gap at the digits printed, within the range that was stated.
By their numbers in this assay, from the lowest: compound 3; then compounds 1, 2 and 4 (each within the scatter of the next).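

In this assay, within the data shown here, the new pair gives no change at the digits printed from compound 2 to compound 4 (within the scatter), the first reading on the double bond itself, which none of the earlier steps could give, since each of them exchanged a group on an aromatic carbon. The large steps among compounds 1, 2 and 3 therefore remain the only sizeable differences in this set, and stating the E configuration adds no further difference to the iodo compound's result. The pair is best read as a comparison of two drawings of the same atoms and bonds, not as a comparison of two known geometries, and the one thing separating the two entries is: the fact that one of compounds 2 and 4 is drawn with a defined configuration and the other without, at the place where they differ

The compounds shown leave open how the Z form of the double bond would read, and whether compound 2 stands for the E form alone or for a mixture of forms. They also leave open whether an amine or a methoxy group on that same aromatic carbon would give a number near compound 3 or near compound 1 and compound 2.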